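Cyclohexyl in place of cyclopropyl on the amide nitrogen

This account rests on a few compounds, and the source may have more. Where it says the series, first, only, none or still open, it means among the compounds named here.

Measured compounds:
- compound 1, `Nc1sc(-c2ccc(Br)cc2)c(-c2ccc(Cl)cc2)c1C(=O)NC1CCCCC1`: 9590 nM
- compound 2, `Nc1sc(-c2ccc([N+](=O)[O-])cc2)c(-c2ccc(Cl)cc2)c1C(=O)NC1CC1`: no result reported

Two compounds share a core that carries an amino group, a chlorophenyl group, a second aryl group and an amide. In a functional assay on A549 cells (Homo sapiens) for cytotoxicity, read by sulforhodamine B assay, with a stated time of 72 h (a higher number here means a weaker inhibitor, a lower number a stronger inhibitor), compound 1 gives 9590 nM, which places it among weak inhibitors of cell growth. Compound 2 differs from compound 1 in two places at once: a nitrophenyl group in place of the bromophenyl group, and a cyclopropyl amide in place of the cyclohexyl amide. For compound 2 in this assay the entry reads "not determined" (no result reported), so compound 2 stands nowhere on the numbers; no result exists for it.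

Compound 3, `Nc1sc(-c2ccc([N+](=O)[O-])cc2)c(-c2ccc(Cl)cc2)c1C(=O)NC1CCCCC1`, is the next step. It keeps the nitrophenyl group of compound 2 and differs from it only in the amide: cyclohexyl in place of cyclopropyl on an amide-type nitrogen. Since compound 2 has no number, no size of step can be read from the data. Compound 1 carries the same cyclohexyl amide and gives 9590 nM in this assay, and that is the only anchor. Compound 3 is therefore expected to fall near compound 1, at an estimated 8000 nM, within a range from 2000 nM to 40000 nM.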

Compound 3, half-maximal inhibitory concentration: 15000 nM
The estimate for compound 3 lay 1.9-fold (0.27 log units) below the measured number, and the stated range covers the measured number.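

With the cyclohexyl amide held fixed, nitro in place of bromo on an aromatic carbon gives a 1.6-fold higher number from compound 1 to compound 3 (0.19 log units; within the scatter), so in this assay compound 1 and compound 3 cannot be told apart, and this exchange on the second aryl group leaves the number within the usual scatter. Within the data shown here, the step that compound 3 was meant to open, cyclohexyl in place of cyclopropyl on the amide-type nitrogen, cannot be read, since compound 2 has no number, and the cyclohexyl amide therefore remains the only amide with measured values here. No measurement shown here bears on why the nitro and bromo compounds read alike.

The compounds shown leave open what any other group on the amide nitrogen would give in this assay, such as a straight hexyl chain, a phenyl ring or a cyclopropyl group on a compound with a reported number. They also leave open whether an amine or a carboxylic acid in place of the nitro on that aromatic carbon would move the number beyond the scatter.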